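Amide Head-Group Swap and Its Expected Effect on Growth Inhibition

This account rests on a few compounds, and the source may have more. Where it says the series, first, only, none or still open, it means among the compounds named here.

Compound 1 `Nc1nc(NCCCc2ccc(C(=O)NO)cc2)nc2nc(-c3ccco3)nn12`: > 100000 nM
Compound 2 `Nc1nc(NCCOc2ccc(C(=O)NO)cc2)nc2nc(-c3ccco3)nn12`: > 100000 nM
Compound 3 `Nc1ccccc1NC(=O)c1ccc(CCCNc2nc(N)n3nc(-c4ccco4)nc3n2)cc1`: 25200 nM

In a functional assay on CT26 cells (Mus musculus) for antiproliferative activity, read by CCK-8 assay, with a stated time of 72 h (on this read-out higher numbers stand for weaker inhibition of growth and lower numbers for stronger inhibition of growth), compound 1 gives > 100000 nM, which is a limit of the assay rather than a number. Compound 2 likewise gives > 100000 nM, again a limit. Compound 3 gives 25200 nM. The change from compound 1 to compound 3 is 2-aminophenyl in place of hydroxy on an amide-type nitrogen, and it brought an at least 3.9-fold lower number from compound 1 to compound 3 (0.59 log units; beyond the scatter); the step is bounded on one side only because of the limit of > 100000 nM in this assay, at which 2 of the 3 values shown sit. The difference between the cores of compound 1 and compound 2 is not broken down here. Compound 4 `Nc1ccccc1NC(=O)c1ccc(OCCNc2nc(N)n3nc(-c4ccco4)nc3n2)cc1` has not yet been measured; it differs from compound 2 by 2-aminophenyl in place of hydroxy on an amide-type nitrogen, the same change at the same place. Compound 2 sits at a limit, > 100000 nM, as compound 1 does. The expected step, resting on the earlier one, is estimated as an at least 3.3-fold lower number from compound 2 to compound 4 (0.52 log units; beyond the scatter). Compound 4 is therefore expected to give about 30000 nM, with a likely range from 10000 nM to 100000 nM.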

Compound 4, concentration for 50% growth inhibition: 32400 nM
Compound 4: the middle estimate sits 1.1-fold (0.03 log units) below what was measured, and the stated range covers the measured number.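

The swap of hydroxy for 2-aminophenyl on the amide-type nitrogen, read in this assay, gave an at least 3.0-fold lower number from compound 2 to compound 4 (0.48 log units; beyond the scatter), so on this second core the change again went with a lower number, and the direction held on both cores shown: the same change on two cores in this assay, an at least 3.9-fold lower number (0.59 log units; beyond the scatter) from compound 1 to compound 3 and an at least 3.0-fold lower number (0.48 log units; beyond the scatter) from compound 2 to compound 4; the limit leaves it open whether they differ

Compound 2 stands at > 100000 nM, which is a limit of the assay and not a number, so this step is bounded on one side only.

The pair of steps shows that the change carries over in direction between these two cores, but it does not fix the true size of either step or show that the change would carry to any further core, and the size stays unknown because of the limit: the limit of > 100000 nM in this assay, at which 2 of the 4 values shown sit.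

The compounds shown leave open whether another group on the amide-type nitrogen, such as an unsubstituted phenyl or a 2-hydroxyphenyl, would bring a step of the same kind. They also leave open whether the change would hold with a longer chain in the linker of either core.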